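Replacing methoxy with methyl in compound 3

The source may report more compounds than this note shows. Statements on the series, on what has been measured and on what is new or still open speak of the compounds shown alone.

In an ADME assay on the whole organism (Mus musculus, strain CD-1) for pharmacokinetics, at a dose of 10 mg/kg by the oral route (on this read-out lower numbers stand for lower exposure and higher numbers for higher exposure at the dose given), compound 1 `COc1cc([C@](O)(CCN(C)C)[C@@H](c2cc3cc(C#N)ccc3nc2OC)c2cccc(C)c2F)cc(OC(F)F)n1` gives 8600 ng.h/mL and compound 2 `COc1cc([C@](O)(CCN(C)C)[C@@H](c2cc3cc(C#N)ccc3nc2OC)c2cccc(OC)c2F)cc(SC)n1` gives 1100 ng.h/mL. Compound 3 `COc1cccc([C@H](c2cc3cc(C#N)ccc3nc2OC)[C@@](O)(CCN(C)C)c2cc(SC)nc(SC)c2)c1F` gives 1100 ng.h/mL, which puts it level with compound 2 and well under compound 1.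

Compound 4 `COc1nc2ccc(C#N)cc2cc1[C@@H](c1cccc(C)c1F)[C@@](O)(CCN(C)C)c1cc(SC)nc(SC)c1` has methyl in place of methoxy on an aromatic carbon, turning 2-fluoro-3-methoxyphenyl into 2-fluoro-3-methylphenyl (methyl in place of methoxy on an aromatic carbon).

Within the data shown here, the only measured step in one place, no change at the digits printed from compound 2 to compound 3 (within the scatter), exchanges methoxy for methylsulfanyl elsewhere in the molecule and does not test this change. Among the measured compounds shown here, compound 1 is the only measured compound with the 2-fluoro-3-methylphenyl group, and its value of 8600 ng.h/mL points upward. However, it also differs from compound 4 in other places, so only part of that gap can be expected to carry over. A modest rise is therefore expected, and the estimated change is a 2.3-fold higher number from compound 3 to compound 4 (0.36 log units; beyond the scatter). For compound 4 the estimated value in this assay is 2500 ng.h/mL, with an expected range of 1000 ng.h/mL to 7000 ng.h/mL.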

Compound 4, area under the concentration-time curve: 2400 ng.h/mL
The estimate for compound 4 lay 1.0-fold (0.02 log units) above the measured number; the measured number falls inside the stated range.
By their numbers in this assay, from the lowest: compounds 2 and 3 (each within the scatter of the next); then compound 4; then compound 1.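

In this assay, among these compounds, methyl in place of methoxy on the aromatic carbon gives a 2.2-fold higher number from compound 3 to compound 4 (0.34 log units; beyond the scatter), the first measured step that tests this position directly. With the 2-fluoro-3-methylphenyl group now common to both compounds, exchanging the group of 12 heavy atoms on the saturated chain carbon for the group of 10 heavy atoms gives a 3.6-fold lower number from compound 1 to compound 4 (0.55 log units; beyond the scatter). The higher number of compound 1 therefore cannot be credited to methyl alone, since methyl accounts for only a modest rise here and a gap beyond the scatter remains at the other place.

On these data alone, it remains open whether ethyl or chloro in place of this methyl would give a similar number. As far as these compounds go, it is also open whether methyl gives the same step when paired with other groups on the saturated chain carbon. No measurement shown here offers an explanation for either step.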